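From methoxy to ethoxy: what to expect for compound 3

This account rests on a few compounds, and the source may have more. Where it says the series, first, only, none or still open, it means among the compounds named here.

Measured compounds:
compound 1, `COc1cc(C)cc2c1C(=O)C=CC2=O`: 21100 nM
compound 2, `COc1cc(C)c(Cl)c2c1C(=O)C=CC2=O`: 19100 nM

Both numbers come from a functional assay on HeLa cells (Homo sapiens) for cytotoxicity, read by XTT assay, with a stated time of 24 h; a lower number here means a stronger inhibitor, a higher number a weaker inhibitor. Within the data shown here, compound 1 stands at the higher of the two numbers, but the only measured step, a 1.1-fold lower number from compound 1 to compound 2 (0.04 log units; within the scatter), lies within the scatter, so the two measured compounds cannot be told apart on these numbers.

Compound 3, `CCOc1cc(C)cc2c1C(=O)C=CC2=O`, has not yet been measured. It differs from compound 1 by methyl in place of hydrogen on a saturated chain carbon bound to an oxygen on an aromatic ring. Among the measured compounds shown here, the one measured step concerns a change at a different place on the shared core, so no measured step bears on this change, and the two values together give no direction. With nothing pointing either way, the expectation for compound 3 in this assay is no step beyond the scatter: an estimated 1.0-fold lower number from compound 1 to compound 3 (0.00 log units; within the scatter). Compound 3 is therefore estimated at 21000 nM, in a range from 8000 nM to 55000 nM.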

Compound 3, half-maximal inhibitory concentration: 29700 nM
For compound 3 the middle estimate is 1.4-fold (0.15 log units) below the measured one; measured number inside the range.
By their numbers in this assay, from the lowest: compounds 2, 1 and 3 (each within the scatter of the next).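

In this assay, the swap from methoxy to ethoxy gives a 1.4-fold higher number from compound 1 to compound 3 (0.15 log units; within the scatter). Among these compounds, this is the first look at this place, a saturated chain carbon bound to an oxygen on an aromatic ring, since the earlier step from chloro concerned a different place on the shared core. Here, methyl in place of hydrogen produces no step beyond the scatter, so in this assay the methoxy and ethoxy compounds cannot be told apart on these numbers.

On these data alone, it remains open whether a longer chain such as propoxy or butoxy, or an amine or a carboxylic acid at the end of the chain, would also stay within the scatter. No measurement at hand speaks to what lies behind this result.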